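A few compounds are considered here, and "the series" means these few. Any claim that something is new, unique, unknown or untested is made for them only; others in the source may bear on it.

Measured so far:
compound 1, `CC(C)CCCOc1cccc(O)c1C(=O)/C=C/c1ccc(O)cc1`: in an assay on THP-1 cells for inhibition of nuclear factor NF-kappa-B complex (Homo sapiens), with stated times of 2 h and 16 h (on this read-out higher numbers stand for weaker inhibition and lower numbers for stronger inhibition), compound 1 gives 11000 nM
compound 2, `O=C(/C=C/c1ccc(O)cc1)c1c(O)cccc1OCC1CCCC1`: in this assay compound 2 gives 13000 nM
compound 3, `CCC(CC)COc1cccc(O)c1C(=O)/C=C/c1ccc(O)cc1`: in this assay compound 3 gives 12000 nM

Compound 3 stands second highest of the three numbers. Its nearest neighbour is compound 2, with a 1.1-fold lower number from compound 2 to compound 3 (0.03 log units; within the scatter); its furthest is compound 1, with a 1.1-fold higher number from compound 1 to compound 3 (0.04 log units; within the scatter). Both gaps lie within the scatter, so the three compounds read as one level in this assay.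

Compound 4, `CC(C)COc1cccc(O)c1C(=O)/C=C/c1ccc(O)cc1`, is the next member of the series. It differs from compound 3 by isopropyl in place of pentan-3-yl on a saturated chain carbon bound to an oxygen on an aromatic ring.

All three measured steps concern the same place, the saturated chain carbon bound to an oxygen on the aromatic ring, and each exchanges one alkyl group for another there: a 1.2-fold higher number from compound 1 to compound 2 (0.07 log units; within the scatter), a 1.1-fold higher number from compound 1 to compound 3 (0.04 log units; within the scatter) and a 1.1-fold lower number from compound 2 to compound 3 (0.03 log units; within the scatter). None of them moves the number beyond the scatter. Among the measured compounds shown here, the change to compound 4 is of the same kind, again an exchange of the alkyl group at that place, and no measured step points in either direction.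

For compound 4 the expected step is therefore no change at the digits printed from compound 3 to compound 4 (within the scatter), that is, no step beyond the scatter in this assay. The estimate for compound 4 is 12000 nM, with a range from 6000 nM to 25000 nM.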

Compound 4, half-maximal inhibitory concentration: 8000 nM
The estimate for compound 4 lay 1.5-fold (0.18 log units) above the measured number; measured number inside the range.
By their numbers in this assay, from the lowest: compounds 4, 1, 3 and 2 (each within the scatter of the next).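

In this assay, isopropyl at the saturated chain carbon bound to an oxygen on an aromatic ring gives a 1.5-fold lower number from compound 3 to compound 4 (0.18 log units; within the scatter) against pentan-3-yl, a 1.6-fold lower number from compound 2 to compound 4 (0.21 log units; within the scatter) against cyclopentyl and a 1.4-fold lower number from compound 1 to compound 4 (0.14 log units; within the scatter) against isopentyl as the group it replaces. The earlier steps compared only the larger alkyl groups with one another; the flat reading now also holds for a group of 3 heavy atoms against the 5 of pentan-3-yl, so compound 1, compound 2, compound 3 and compound 4 read as one level and no alkyl exchange shown at this place moves the number beyond the scatter. Nothing available explains this flat reading at the position.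

Every group shown at this place is a saturated carbon group, so it remains open whether an amine, a carboxylic acid or a much longer chain such as dodecyl would move the number beyond the scatter. Every step shown also falls at this one place, which leaves open how far changes elsewhere on the shared core would shift the number.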